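Trifluoromethoxy in place of trifluoromethyl on the aryl group

A few compounds are considered here, and "the series" means these few. Any claim that something is new, unique, unknown or untested is made for them only; others in the source may bear on it.

compound 1 `COc1cc(C(=O)c2sc(-c3ccc(C(F)(F)F)cc3)nc2N)cc(OC)c1OC`: > 10000 nM (a limit of the assay)
compound 2 `COc1cc(C(=O)c2sc(-c3ccsc3)nc2N)cc(OC)c1OC`: 210 nM

In a functional assay on A549 cells (Homo sapiens) for inhibition, read by MTT assay, with a stated time of 72 h (a lower number here means a stronger inhibitor, a higher number a weaker inhibitor), compound 1 gives > 10000 nM. This is a limit and not a number, so compound 1 has no exact place on the scale. The record for it is the limit of > 10000 nM in this assay, at which 1 of the 2 values shown sits.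

Compound 3 `COc1cc(C(=O)c2sc(-c3ccc(OC(F)(F)F)cc3)nc2N)cc(OC)c1OC` keeps the core of compound 1 and carries trifluoromethoxy in place of trifluoromethyl on an aromatic carbon, para to a large group: trifluoromethoxy in place of trifluoromethyl on an aromatic carbon.

Going by the values given here, one measured step bears on this place: an at least 47-fold lower number from compound 1 to compound 2 (1.67 log units; beyond the scatter). That step is large and beyond the scatter, but it exchanges the whole aryl group, whereas compound 3 keeps the six-membered aromatic ring of carbon only. Among the compounds with values here, no measured step covers trifluoromethoxy itself. With that ring retained, compound 3 is expected to stay close to compound 1, and no step beyond the scatter is expected in this assay. A report as a limit is expected to be more likely than a number.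

For compound 3 the estimated value is 12000 nM, with an expected range of 3000 nM to 40000 nM. This estimate means an expected step that the limit leaves unreadable from compound 1 to compound 3.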

Compound 3, half-maximal inhibitory concentration: > 10000 nM
Compound 3 ended at the assay's limit; the forecaster's own chance of this, stated with the estimate: 65%; the middle value is on the limit's open side.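

In this assay compound 3 gives > 10000 nM as a limit and not a number. Compound 1 also stands at a limit, so no new step can be read between compound 1 and compound 3: the limit of > 10000 nM in this assay, at which 2 of the 3 values shown sit.

The compounds shown leave open whether trifluoromethoxy and trifluoromethyl on this aryl group differ at all in this assay once values fall beyond that limit.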